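The source may report more compounds than this note shows. Statements on the series, on what has been measured and on what is new or still open speak of the compounds shown alone.

Measured so far in a functional assay on the whole organism (strain Wistar albino) for inhibition, with Rattus norvegicus as the target, read by paw edema, with a stated time of 3 h, at a dose of 25 mg/kg by the oral route; on this read-out higher numbers stand for more inhibition at the one dose given (going by the name of the read-out) and lower numbers for less inhibition:
- compound 1, `CSc1nn(-c2ccccc2)c2nc(Nc3ccccc3)n(-c3ccccc3)c(=O)c12`: 25.4%
- compound 2, `O=c1c2c(Nc3ccccc3)nn(-c3ccccc3)c2nc(Nc2ccccc2)n1-c1ccccc1`: 17.1%
- compound 3, `NS(=O)(=O)c1ccc(-n2nc(Nc3ccccc3)c3c(=O)n(-c4ccccc4)c(Nc4ccccc4)nc32)cc1`: 39.7%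

Compound 2 and compound 1 lie within the scatter of each other, a number 8.3 percentage points lower from compound 1 to compound 2 (within the scatter), the change there being anilino in place of methylsulfanyl on an aromatic carbon. Compound 3 lies beyond the scatter, a number 22.6 percentage points higher from compound 2 to compound 3 (beyond the scatter), with sulfamoyl in place of hydrogen on an aromatic carbon.

Compound 4, `Cc1ccc(Nc2nn(-c3ccccc3)c3nc(Nc4ccccc4)n(-c4ccccc4)c(=O)c23)cc1`, differs from compound 2 by methyl in place of hydrogen on an aromatic carbon.

Neither measured step bears directly on this change: the step from compound 1 to compound 2 replaces one group on the core by another, and the step from compound 2 to compound 3 adds sulfamoyl on a different phenyl. Going by the values given here, no step with methyl in place of hydrogen on the anilino phenyl has been measured, so no movement beyond the scatter is expected. The step from compound 2 is estimated at a number 2.9 percentage points higher from compound 2 to compound 4 (within the scatter). Compound 4 is expected to give 20%, with a range from 8% to 32%.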

Compound 4, a percentage reported as inhibition, in the whole organism at one dose (the size of the read-out at that dose, not a potency): 32.9%
The estimate for compound 4 lay 12.9 percentage points below the measured number; measured number outside the range, above it.
By their numbers in this assay, from the lowest: compounds 2, 1, 4 and 3 (each within the scatter of the next, the first and the last beyond it).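

In this assay, a single methyl on an aromatic carbon of the anilino phenyl, para to a large group, moves the number beyond the scatter: a number 15.8 percentage points higher from compound 2 to compound 4 (beyond the scatter). Going by these compounds alone, this position therefore responds to a small change, which the earlier steps at the core carbon and on the other phenyl did not show. Against methylsulfanyl, (4-methylphenyl)amino gives a number 7.5 percentage points higher from compound 1 to compound 4 (within the scatter), so the two groups are not separated in this read-out, and no measurement bears on why the methyl changes the number.

On these data alone, it remains open whether ethyl, methoxy or chlorine on the same carbon would give a step of similar size. Also open, as far as these compounds go, is how methyl and sulfamoyl would behave together in one compound.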